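Lengthening the ester chain by one carbon

The source may hold more compounds than are shown below. What is called first, only, known or untested is meant among the compounds shown, and "the series" means these compounds.

Measured so far:
compound 1 `CCCCCCCCOC(=O)CCC(=O)N1CCN(CCCOc2cc3c(Nc4ccc(F)c(Cl)c4)ncnc3cc2OC)CC1`: 48.7%
compound 2 `CCCCCCCCCCCCCCCCCCOC(=O)CCC(=O)N1CCN(CCCOc2cc3c(Nc4ccc(F)c(Cl)c4)ncnc3cc2OC)CC1`: 91%

In a functional assay on A549 cells (Homo sapiens) for cytotoxicity, read by MTT assay, with a stated time of 24 h, tested at 40 uM (a lower number here means a stronger effect, a higher number a weaker effect of the compound at the concentration tested), compound 2 stands highest of the two numbers, and compound 1 sits well below it. Going by the values given here, the only measured step, a number 42.3 percentage points higher from compound 1 to compound 2 (beyond the scatter), was large. Compound 3 `CCCCCCCCCCCCCCCCCCCOC(=O)CCC(=O)N1CCN(CCCOc2cc3c(Nc4ccc(F)c(Cl)c4)ncnc3cc2OC)CC1` differs from compound 2 by methyl in place of hydrogen on a saturated chain carbon, ten or more bonds along the chain from an oxygen next to a carbonyl group. That earlier step is the one that bears on this change, but it added far more carbon; the present change is a single methyl at the chain end. Compound 3 is therefore expected to show no change at the digits printed from compound 2 to compound 3 (within the scatter), no step beyond the scatter. Compound 3 is estimated at 91%, within 78% to 100%.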

Compound 3, a percentage reported as activity, at one concentration (the size of the read-out at that concentration, not a potency): 92.3%
Beside the measured number, compound 3's estimate is 1.3 percentage points below it; the measured number falls inside the stated range.
By their numbers in this assay, from the lowest: compound 1; then compounds 2 and 3 (each within the scatter of the next).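

In this assay, methyl in place of hydrogen on a saturated chain carbon gives a number 1.3 percentage points higher from compound 2 to compound 3 (within the scatter) and so leaves the read-out of compound 2 within the scatter. Compound 3 keeps the large gap to the shorter chain, with a number 43.6 percentage points higher from compound 1 to compound 3 (beyond the scatter) as its step. No available evidence accounts for either step. On these data alone, what remains open is how the read-out runs for chains longer than that of compound 1 yet shorter than that of compound 2, and whether an amine or a carboxylic acid on this chain would give a different number.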